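Three Limits and a Branched Chain: Compound 4 Expected

The source may hold more compounds than are shown below. What is called first, only, known or untested is meant among the compounds shown, and "the series" means these compounds.

The series gathers three acids measured in a functional assay on CHO cells with sphingosine 1-phosphate receptor 4 (Homo sapiens) as the target, read by GTPgammaS binding; a higher number here means that more compound is needed for the effect, a lower number that less compound is needed. Compound 1 `CCOc1ccc(-c2nc(-c3ccc(CCC(=O)O)cc3C)no2)cc1C(F)(F)F` reaches only the assay limit, giving > 10000 nM in this assay. Compound 2 `Cc1cc(CCC(=O)O)ccc1-c1noc(-c2ccc(C3CCCCC3)cc2)n1` likewise stops at the limit, with > 10000 nM. Compound 3 `CCCCc1ccc(-c2nc(-c3ccc(CCC(=O)O)cc3C)no2)nc1` stands in the same place: in this assay compound 3 gives > 10000 nM, a limit and not a number. Nothing sets compound 3 apart from the other two, because the limit of > 10000 nM in this assay, at which 3 of the 3 values shown sit, shows that every value in the set sits at that limit.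

The untested compound 4 `Cc1cc(CCC(=O)O)ccc1-c1noc(-c2ccc(CC(C)C)cn2)n1` keeps the atoms of compound 3 and joins them differently: isopropyl in place of propyl on a saturated chain carbon bound to an aromatic carbon. Going by the values given here, no pair of measured compounds with a single difference exists here, so the size of the step cannot be read from the data. Three compounds all at the limit give no sign that a rearranged chain would move the number into measurable range, and the step is expected to be none beyond the scatter, again reported as a limit. The expected step that the limit leaves unreadable from compound 3 to compound 4 is therefore essentially flat. Compound 4 is estimated at 15000 nM, within 5000 nM to 50000 nM.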

Compound 4, half-maximal effective concentration: > 10000 nM
Compound 4: no number, only a limit (the forecaster's own chance of this, stated with the estimate: 85%); the middle value does not contradict the limit.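

Going by these compounds alone, compound 3 and compound 4 both give only a limit and not a number, so no step between them can be read. In this assay the compounds shown leave open whether propyl and isopropyl differ at all, and which structure would give a measurable value.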